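Acylurea aryl swap on the hydrazone-bearing thiazole series

This account rests on a few compounds, and the source may have more. Where it says the series, first, only, none or still open, it means among the compounds named here.

Three compounds of the series have numbers in a functional assay on A549 cells (Homo sapiens) for inhibition, read by MTT assay, with a stated time of 72 h; a lower number here means a stronger inhibitor, a higher number a weaker inhibitor. Compound 1 `CN(C(=O)NC(=O)c1c(F)cccc1F)c1nc(C(F)(F)F)c(C(=O)N/N=C/c2cccc(C(F)(F)F)c2)s1` gives 27.6 ug/mL. Compound 2 `CN(C(=O)NC(=O)c1ccccc1F)c1nc(C(F)(F)F)c(C(=O)N/N=C/c2cc(C(F)(F)F)cc(C(F)(F)F)c2)s1` gives 5.43 ug/mL. Compound 3 `CN(C(=O)NC(=O)c1ccc(F)c(F)c1)c1nc(C(F)(F)F)c(C(=O)N/N=C/c2ccccc2C(F)(F)F)s1` gives 6.96 ug/mL. Compound 2 stands at the lowest of the three numbers; compound 3 sits within the scatter of it, so the two cannot be ranked against each other, while compound 1 lies beyond the scatter above both. Within the data shown here, no two of the three measured compounds differ in a single place, so no step between measured compounds can be read off, and the effect of the acyl aryl group alone is not isolated in the measured set.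

Compound 4 `CN(C(=O)NC(=O)c1ccc(C(F)(F)F)cc1)c1nc(C(F)(F)F)c(C(=O)N/N=C/c2cc(C(F)(F)F)cc(C(F)(F)F)c2)s1` has not been measured. It differs from compound 2 in one place: 4-(trifluoromethyl)phenyl in place of 2-fluorophenyl on a carbonyl carbon. The rest of the molecule, including the bis(trifluoromethyl)phenyl hydrazone side, is kept. Among the measured compounds shown here, with no isolated step for this position in hand, the expectation for this change in this assay is a small one, of no settled direction and not beyond the scatter. The step from compound 2 to compound 4 is estimated at a 1.3-fold higher number from compound 2 to compound 4 (0.11 log units; within the scatter). For compound 4 the expected value is 7 ug/mL, with a range from 3 ug/mL to 16 ug/mL.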

Compound 4, half-maximal inhibitory concentration: 5.9 ug/mL
Beside the measured number, compound 4's estimate is 1.2-fold (0.07 log units) above it; low and high end bracket the measured number.
By their numbers in this assay, from the lowest: compounds 2, 4 and 3 (each within the scatter of the next); then compound 1.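

In this assay, 4-(trifluoromethyl)phenyl in place of 2-fluorophenyl on a carbonyl carbon gives a 1.1-fold higher number from compound 2 to compound 4 (0.04 log units; within the scatter), and this is the only isolated step at this position among the compounds shown. Among these compounds, it supplies what the earlier compounds could not: with the bis(trifluoromethyl)phenyl hydrazone side kept, this position accepts a larger aryl group, carrying trifluoromethyl instead of fluorine, with no difference beyond the scatter. No supporting measurement accompanies this result, so the data offer no explanation for it.

Compound 1 and compound 3 each differ from compound 2 and compound 4 in more than one place, so the number of compound 1 cannot be assigned to its acyl aryl group or to its hydrazone side. As far as these compounds go, it remains open whether this tolerance holds on other hydrazone sides, and whether it extends to a phenyl carrying a carboxylic acid or a dimethylamino group, or to a saturated cyclohexyl group, on the same carbonyl carbon.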